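Benzyloxy Variation on a Shared Core: Compound 1 to Compound 4

The source may report more compounds than this note shows. Statements on the series, on what has been measured and on what is new or still open speak of the compounds shown alone.

compound 1 `CC(C)=C1C(=O)Nc2ccc(OCc3ccc(F)cc3)cc21` — "not active" (no number reported)
compound 2 `Cc1ccc(COc2ccc3c(c2)C(C(C)C)C(=O)N3)cc1` — "not active" (no number reported)
compound 3 `Cn1c(=O)[nH]c2ccc(OCc3cccc(Cl)c3)cc21` — 8.89%

In an assay on cells for inhibition of Amine oxidase [flavin-containing] B (Homo sapiens), read by fluorescence, with stated times of 30 min and 15 min, tested at 1 uM (a lower number here means less inhibition, a higher number more inhibition at the concentration tested (going by the name of the read-out)), compound 1 gives "not active" (no number reported), so no number stands for it. Compound 2 likewise gives "not active" (no number reported) in this assay. Compound 3 gives 8.89% in this assay, a low figure. Compound 1 therefore stands without a single value, alongside one further entry of the same kind. Compound 4 `CC(C)=C1C(=O)Nc2ccc(OCc3cccc(C)c3)cc21` differs from compound 1 in one place: 3-methylphenyl in place of 4-fluorophenyl on a saturated chain carbon bound to an oxygen on an aromatic ring. Within the data shown here, no step between two measured compounds covers this change, so the expected effect in this assay is none beyond the scatter, with low inhibition the likely outcome. Compound 4 is expected to give about 5%, in the range 0% to 15%, with a fair chance that the assay again reports no number.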

Compound 4, a percentage reported as inhibition, at one concentration (the size of the read-out at that concentration, not a potency): "not active" (no number reported)
No number was reported for compound 4; there is nothing to compare the estimate with.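

In this assay neither compound 1 nor compound 4 carries a number, so no step can be read between them, and no evidence bears on this result. The compounds shown leave open whether 3-methylphenyl in place of 4-fluorophenyl changes inhibition at all.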